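Acetyl on the amino group of compound 3

This account rests on a few compounds, and the source may have more. Where it says the series, first, only, none or still open, it means among the compounds named here.

Compound 1 `COc1ccc(/C=C\c2ccc3ccccc3c2)cc1N` gives > 20000 nM in a functional assay on A549 cells (Homo sapiens) for inhibition (on this read-out higher numbers stand for weaker inhibition and lower numbers for stronger inhibition), which is a limit and not a number. In this assay compound 2 `COc1cc(/C=C\c2ccc3ccccc3c2)cc([N+](=O)[O-])c1OC` gives 590 nM and compound 3 `COc1cc(/C=C\c2ccc3ccccc3c2)cc(N)c1OC` gives 1640 nM, the higher of these two numbers. Compound 4 `COc1cc(/C=C\c2ccc3ccccc3c2)cc(NC(C)=O)c1OC` carries acetyl in place of hydrogen on a nitrogen on an aromatic ring, amino to acetamido: acetyl in place of hydrogen on a nitrogen on an aromatic ring. The change at this same place shows a 2.8-fold higher number from compound 2 to compound 3 (0.44 log units; beyond the scatter), a modest step. The methoxy change shows an at least 12-fold lower number from compound 1 to compound 3 (1.08 log units; beyond the scatter), a large step resting on a limit. No acylated nitrogen has been measured yet, so a modest step towards a higher number is expected in this assay, guided by a 2.8-fold higher number from compound 2 to compound 3 (0.44 log units; beyond the scatter). The estimated step is a 2.4-fold higher number from compound 3 to compound 4 (0.39 log units; beyond the scatter). For compound 4 the estimate is 4000 nM, with an expected range of 1000 nM to 16000 nM.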

Compound 4, half-maximal inhibitory concentration: > 5000 nM
Compound 4: a limit, no number; the forecaster's own chance of this, stated with the estimate: 20%; middle value at least 1.2-fold (0.09 log units) from the limit.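

In this assay compound 4 stands at a limit and not at a number: the limit of > 5000 nM in this assay, at which 1 of the 4 values shown sits.

Acetyl on the nitrogen gives an at least 3.0-fold higher number from compound 3 to compound 4 (0.48 log units; beyond the scatter), and acetamido in place of nitro gives an at least 8.4-fold higher number from compound 2 to compound 4 (0.92 log units; beyond the scatter). At this place, nitro in compound 2, amino in compound 3 and acetamido in compound 4 now run from the lowest number to the highest, so acylating this nitrogen does not restore the number of the nitro compound.

The limit leaves the full size of both steps open. Also open, on these data alone, is how a methyl or a methanesulfonyl group on this nitrogen would read.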